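Chloro for methyl on the fused ring of compound 3

The compounds below may be only part of what the source reports. "The series", "measured", "known", "first", "only" and "open" are said of these compounds alone.

Among the measured compounds shown here, compound 3 `Cc1ccc2nc(Cl)c(Cn3cc(Cn4cnn(-c5ccccc5)c4=O)nn3)cc2c1` stands at 478 ug/mL in an ADME assay on HEK293 cells (Homo sapiens) for cytotoxicity, read by MTT assay (on this read-out lower numbers stand for stronger inhibition and higher numbers for weaker inhibition), the lowest of the three numbers measured so far. Compound 1 `COc1ccc(-n2ncn(Cc3cn(Cc4cc5ccccc5nc4Cl)nn3)c2=O)cc1` gives 958 ug/mL in this assay, and compound 2 `COc1ccc(-n2ncn(Cc3cn(Cc4cc5cc(Cl)ccc5nc4Cl)nn3)c2=O)cc1` gives 1060 ug/mL in this assay. The gap from compound 3 to compound 1 is within the scatter; the gap to compound 2 is just beyond it. Compound 4 `O=c1n(Cc2cn(Cc3cc4cc(Cl)ccc4nc3Cl)nn2)cnn1-c1ccccc1` is not yet measured. It differs from compound 3 by chloro in place of methyl on an aromatic carbon. For the measured compounds named here, the single measured step, a 1.1-fold higher number from compound 1 to compound 2 (0.04 log units; within the scatter), adds a chloro where compound 1 carries hydrogen and stayed within the scatter; it bears only loosely on the present change, since here a methyl leaves. Going by the values given here, no measured pair sets methyl against chloro at this place. On that basis the step expected is a 1.0-fold higher number from compound 3 to compound 4 (0.02 log units; within the scatter), nothing beyond the scatter. Compound 4 is therefore estimated at 500 ug/mL in this assay, with a range from 250 ug/mL to 1000 ug/mL.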

Compound 4, half-maximal inhibitory concentration: 459 ug/mL
Compound 4: the middle estimate sits 1.1-fold (0.04 log units) above what was measured; the range from low to high includes it.
By their numbers in this assay, from the lowest: compounds 4, 3, 1 and 2 (each within the scatter of the next, the first and the last beyond it).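

Working notes on the series: in this assay, the first direct comparison of methyl and chloro at this place gives a 1.0-fold lower number from compound 3 to compound 4 (0.02 log units; within the scatter), so the two groups cannot be told apart here. Among the compounds shown here, the only one-place step that lies beyond the scatter falls elsewhere in the molecule, where hydrogen in place of methoxy on an aromatic carbon gives a 2.3-fold lower number from compound 2 to compound 4 (0.36 log units; beyond the scatter). No measured finding is available to explain either step.

On these data alone, only hydrogen, methyl and chloro appear at this place, so the reading with an amine or a carboxylic acid there remains open. For the compounds shown here, also open is whether the methoxy step carries over when hydrogen or methyl occupies this place, since the single pair setting methoxy against hydrogen carries chloro.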